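The compounds below may be only part of what the source reports. "The series", "measured", "known", "first", "only" and "open" are said of these compounds alone.

Measured so far in a functional assay on CRL2813 cells (Homo sapiens) for cytotoxicity, read by sulforhodamine B assay, with a stated time of 5 days; a higher number here means a weaker inhibitor, a lower number a stronger inhibitor:
compound 1 `O=C(Nc1ccc(Br)cc1)N[C@H]1CC[C@H](Oc2ccc(F)cc2)CC1` — > 20000 nM
compound 2 `COc1cccc(NC(=O)N[C@H]2CC[C@H](Oc3ccc(F)cc3)CC2)c1` — 14000 nM
compound 3 `O=C(Nc1cccc(C(F)(F)F)c1)N[C@H]1CC[C@H](Oc2ccc(OC(F)(F)F)cc2)CC1` — 690 nM

Compound 1 stands at the limit of this assay, > 20000 nM, which is a bound and not a number, as noted in the limit of > 20000 nM in this assay, at which 1 of the 3 values shown sits. Among the compounds with values here, the single step out of compound 1 that is measured, an at least 1.4-fold lower number from compound 1 to compound 2 (0.15 log units; that floor lies within the scatter), has a floor that lies within the scatter, so compound 2 sits only marginally clear of the limit. Differing from compound 1 at both ends of the shared core, compound 3 gives 690 nM and carries no single-change step to it.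

Compound 4 `O=C(Nc1ccccc1Cl)N[C@H]1CC[C@H](Oc2ccc(F)cc2)CC1` differs from compound 1 by 2-chlorophenyl in place of 4-bromophenyl on an amide-type nitrogen. Within the data shown here, no measured step covers this exchange; the only neighbouring step, from compound 1 to compound 2, is at the scatter floor. Compound 4 is therefore expected near the limit, with the step of a number no higher from compound 1 to compound 4 (the limit leaves the size open) not clearly beyond scatter. The estimate for compound 4 is 20000 nM, range 7000 nM to 60000 nM.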

Compound 4, half-maximal inhibitory concentration: 9100 nM
For compound 4 the middle estimate is 2.2-fold (0.34 log units) above the measured one, and the stated range covers the measured number.
By their numbers in this assay, from the lowest: compound 3; then compounds 4 and 2 (each within the scatter of the next). At a limit, above all of these: compound 1.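

In this assay, within the data shown here, 2-chlorophenyl on an amide-type nitrogen gives the first step at this position that clears the scatter, an at least 2.1-fold lower number from compound 1 to compound 4 (0.34 log units; beyond the scatter). Against 3-methoxyphenyl, the same group gives a 1.5-fold lower number from compound 2 to compound 4 (0.19 log units; within the scatter), which leaves these two groups unseparated here. On these data alone, the full size of the first step stays open, since its starting point is a limit: the limit of > 20000 nM in this assay, at which 1 of the 4 values shown sits.

Still open, as far as these compounds go, is whether 4-chlorophenyl would read like 2-chlorophenyl, which would separate the halogen from its place on the ring. Also open, from the compounds shown here alone, is how a phenyl ring carrying an amine or a carboxylic acid would read at this position.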